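The compounds below may be only part of what the source reports. "The series", "measured", "known", "first", "only" and "open" are said of these compounds alone.

Measured so far:
- compound 1, `O=C(/C(=C\c1ccc(O)cc1O)Sc1ccccc1Br)c1ccc(Cl)cc1`: 50000 nM
- compound 2, `O=C(/C(=C\c1c(O)cc(O)cc1O)Sc1ccccc1Br)c1ccc(Br)cc1`: a limit only
- compound 3, `O=C(/C(=C\c1ccc(O)cc1O)Sc1ccccc1Br)c1ccc(Br)cc1`: 50000 nM

All three were tested in a functional assay on DU-145 cells (Homo sapiens) for inhibition, read by trypan blue exclusion, with a stated time of 96 h; on this read-out higher numbers stand for weaker inhibition of growth and lower numbers for stronger inhibition of growth. Compound 1 gives 50000 nM. Compound 3 gives 50000 nM. For compound 2 the assay reports only a limit, > 100000 nM, and not a number (the limit of > 100000 nM in this assay, at which 1 of the 3 values shown sits). Compound 3 therefore stands level with compound 1, since no change at the digits printed from compound 1 to compound 3 (within the scatter). The other measured step, an at least 2.0-fold lower number from compound 2 to compound 3 (0.30 log units; that floor lies within the scatter), concerns the removal of one hydroxy group from a trihydroxyphenyl ring, and its floor lies within the scatter.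

Compound 4, `O=C(/C(=C\c1ccccc1O)Sc1ccccc1Br)c1ccc(Br)cc1`, is not yet measured. It differs from compound 3 by hydrogen in place of hydroxy on an aromatic carbon, so that the 2,4-dihydroxyphenyl of compound 3 becomes a 2-hydroxyphenyl. Among the measured compounds shown here, the only step of the same kind is the one from compound 2 to compound 3, which gave a number at least modestly lower but not clearly beyond the scatter. Compound 4 is therefore expected to sit close to compound 3, with the step of no change at the digits printed from compound 3 to compound 4 (within the scatter) expected to lie within the scatter. The estimate for compound 4 is 50000 nM, with a range from 20000 nM to 100000 nM.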

Compound 4, concentration for 50% growth inhibition: 50000 nM
The estimate for compound 4 equals the measured number at the digits printed; low and high end bracket the measured number.
By their numbers in this assay, from the lowest: compounds 1, 3 and 4 (each within the scatter of the next). At a limit, above all of these: compound 2.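

In this assay, putting 2-hydroxyphenyl in place of 2,4-dihydroxyphenyl gives no change at the digits printed from compound 3 to compound 4 (within the scatter), so the growth inhibition seen here holds without this hydroxy group, which sits meta to the remaining hydroxy group and para to a large group. Among the compounds shown here, this is the first step of hydrogen in place of hydroxy with a number at both ends, so it can be read as a real absence of change at this level rather than as a floor. As far as these compounds go, putting 2-hydroxyphenyl in place of 2,4,6-trihydroxyphenyl gives an at least 2.0-fold lower number from compound 2 to compound 4 (0.30 log units; that floor lies within the scatter), but that step starts from a limit of the assay and not a number, so its true size stays unknown.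

The compounds shown leave open whether the remaining hydroxy group matters at all. They also leave open whether an amine or a methoxy group in place of the lost hydroxy group would move the number.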